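Aryl amides on a quinoline core: furan to chlorophenyl

This account rests on a few compounds, and the source may have more. Where it says the series, first, only, none or still open, it means among the compounds named here.

Measured so far:
- compound 1 `CCN1CCN(c2cc(C)c3cc(NC(=O)c4ccc(OC)cc4)ccc3n2)CC1`: 9000 nM
- compound 2 `CCN1CCN(c2cc(C)c3cc(NC(=O)c4ccco4)ccc3n2)CC1`: 37500 nM

Compound 1 carries a 4-methoxyphenyl group on the amide carbonyl and, in a functional assay on SK-BR-3 cells (Homo sapiens) for antiproliferative activity, read by MTT assay, with a stated time of 72 h (a higher number here means a weaker inhibitor, a lower number a stronger inhibitor), compound 1 gives 9000 nM. Compound 2 has furan-2-yl in that place, and in this assay compound 2 gives 37500 nM. Going by the values given here, of the two numbers known, compound 2 stands highest, and its only neighbour is compound 1, a step recorded as a 4.2-fold higher number from compound 1 to compound 2 (0.62 log units; beyond the scatter).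

The next compound, compound 3 `CCN1CCN(c2cc(C)c3cc(NC(=O)c4ccccc4Cl)ccc3n2)CC1`, differs from compound 2 by 2-chlorophenyl in place of furan-2-yl on a carbonyl carbon. Among the compounds with values here, the one measured step bears on this directly but in the reverse sense: moving from a six-membered carbon ring to furan-2-yl raised the number, so the return to a six-membered carbon ring, here bearing chlorine, is expected to lower it again. The 2-chlorophenyl group is not the same as 4-methoxyphenyl, so the return need not be complete. Compound 3 is therefore expected to give 13000 nM in this assay, within 5000 nM to 32000 nM, a step estimated as a 2.9-fold lower number from compound 2 to compound 3 (0.46 log units; beyond the scatter).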

Compound 3, half-maximal inhibitory concentration: > 50000 nM
Compound 3: no number, only a limit (the forecaster's own chance of this, stated with the estimate: 10%); middle value at least 3.8-fold (0.58 log units) away from the limit.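

In this assay compound 3 gives > 50000 nM, which is a limit of the assay and not a number, so this series now includes a group on the carbonyl carbon for which the assay yields no value: the limit of > 50000 nM in this assay, at which 1 of the 3 values shown sits. Against furan-2-yl the change reads as an at least 1.3-fold higher number from compound 2 to compound 3 (0.12 log units; that floor lies within the scatter), so the floor alone does not separate the 2-chlorophenyl group from furan-2-yl, and the order of these two compounds cannot be stated. Against 4-methoxyphenyl the change reads as an at least 5.5-fold higher number from compound 1 to compound 3 (0.74 log units; beyond the scatter), which shows that a six-membered aromatic ring of carbon only on the carbonyl carbon does not by itself bring the lower number of compound 1, and that what the ring carries, or where it carries it, makes a difference.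

The 4-methoxyphenyl and 2-chlorophenyl groups differ both in the substituent and in its place on the ring, so the compounds shown cannot tell these two effects apart. From the compounds shown here alone, how a plain phenyl ring, or a phenyl ring carrying an amine, would stand on the same carbonyl carbon also remains open.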